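The compounds below may be only part of what the source reports. "The series", "measured", "known", "first", "only" and "open" are said of these compounds alone.

Working notes on the series. In a functional assay on SK-MEL-5 cells (Homo sapiens) for cytotoxicity, read by sulforhodamine B assay, with a stated time of 48 h (a lower number here means a stronger inhibitor of growth, a higher number a weaker inhibitor of growth), compound 1 `CC1=C(C(=O)Nc2ccc(Cl)c(Cl)c2)C(c2cccc(O)c2)NC(=S)N1` gives 10000 nM, the highest of the three numbers. Compound 2 `CC1=C(C(=O)Nc2ccc(F)c(Cl)c2)C(c2cccc(Cl)c2)NC(=S)N1` gives 8320 nM and compound 3 `CC1=C(C(=O)Nc2ccc(Cl)c(Cl)c2)C(c2cccc(Oc3ccccc3)c2)NC(=S)N1` gives 7940 nM; both lie within the scatter of compound 1, so no order among the three can be read from these numbers.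

Among the compounds with values here, the only single-point step among the measured compounds is a 1.3-fold lower number from compound 1 to compound 3 (0.10 log units; within the scatter), which replaces the hydrogen of the hydroxyl on the aromatic ring with a phenyl and changes nothing beyond the scatter.

Compound 4 `CC1=C(C(=O)Nc2ccc(Cl)c(Cl)c2)C(c2ccccc2Cl)NC(=S)N1` differs from compound 1 by 2-chlorophenyl in place of 3-hydroxyphenyl on a saturated ring carbon. Within the data shown here, no measured step changes this ring in the same way; compound 2 carries a 3-chlorophenyl on the same saturated ring carbon, but also a different amide aryl, so its value shows only that a chlorophenyl at this position also sits near the upper end of the numbers. Among the measured compounds shown here, the one step that touches this ring stayed within the scatter, and the three values themselves span less than the scatter. On that basis a step of a 1.1-fold lower number from compound 1 to compound 4 (0.05 log units; within the scatter) is expected, that is, nothing beyond the scatter, with compound 4 estimated at 9000 nM and a range of 3500 nM to 25000 nM in this assay.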

Compound 4, concentration for 50% growth inhibition: 10000 nM
Beside the measured number, compound 4's estimate is 1.1-fold (0.05 log units) below it, and the stated range covers the measured number.
By their numbers in this assay, from the lowest: compounds 3, 2, 1 and 4 (each within the scatter of the next).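

In this assay, within the data shown here, the exchange of 3-hydroxyphenyl for 2-chlorophenyl on the saturated ring carbon gives no change at the digits printed from compound 1 to compound 4 (within the scatter) and is the first step to replace this whole aryl group rather than alter its hydroxyl. The change removes the hydroxyl, introduces chlorine and places the substituent differently on the aromatic ring, yet the number stays within the scatter, so this pair shows no dependence on the hydrogen-bond donor and acceptor counted on the 3-hydroxyphenyl. Nothing available bears on why the number holds across this exchange.

Still open, on these data alone, is whether any group on this saturated ring carbon can move the number beyond the scatter, since the single-place steps here, which span a hydroxyl, a phenyl ether and a chlorine on the aryl group, all stay within it. An aminomethyl or carboxylic acid group on this phenyl ring, or a saturated cyclohexyl ring or longer alkyl chain in place of the aryl group, would test that question against the core of compound 1.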